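A 3-Bromophenyl Replacement in Compound 1

This account rests on a few compounds, and the source may have more. Where it says the series, first, only, none or still open, it means among the compounds named here.

In a functional assay on A549 cells (Homo sapiens) for inhibition, read by sulforhodamine B assay, with a stated time of 72 h (on this read-out lower numbers stand for stronger inhibition and higher numbers for weaker inhibition), compound 1 (`COc1cc2c(Nc3ccc(F)c(Cl)c3)ncnc2cc1OCCCCCCn1ccnc1[N+](=O)[O-]`) gives 13400 nM. Compound 2 (`COc1cc2c(Nc3ccc(F)c(Cl)c3)ncnc2cc1OCCOCCn1ccnc1[N+](=O)[O-]`) gives 12900 nM, and compound 3 (`COc1cc2c(Nc3ccc(OCc4cccc(F)c4)c(Cl)c3)ncnc2cc1OCCCCCn1ccnc1[N+](=O)[O-]`) gives 19900 nM. Compound 1 therefore stands among three values that all lie within the usual scatter of one another, with compound 2 as its nearest neighbour and compound 3 as its furthest.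

Compound 4 (`COc1cc2c(Nc3cccc(Br)c3)ncnc2cc1OCCCCCCn1ccnc1[N+](=O)[O-]`) has not yet been measured. It departs from compound 1 in one place: 3-bromophenyl in place of 3-chloro-4-fluorophenyl on a nitrogen on an aromatic ring. In words, 3-bromophenyl stands in place of 3-chloro-4-fluorophenyl on a nitrogen on an aromatic ring.

Going by the values given here, the only measured single-place step, a 1.0-fold lower number from compound 1 to compound 2 (0.02 log units; within the scatter), lies within the scatter, but it alters the chain and not this group, so it bears on the change only indirectly. Among the compounds with values here, no measured step alters the group on that nitrogen alone. Compound 3 carries a different group there, along with a different chain, and its 19900 nM remains within the scatter of compound 1.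

No shift beyond the scatter is therefore expected in this assay. The estimate amounts to a 1.0-fold higher number from compound 1 to compound 4 (0.02 log units; within the scatter), which is expected to stay within the scatter. For compound 4 the estimated value is 14000 nM, with an expected range of 7500 nM to 26000 nM.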

Compound 4, half-maximal inhibitory concentration: 30200 nM
Beside the measured number, compound 4's estimate is 2.2-fold (0.33 log units) below it; the whole stated range lies below it.
By their numbers in this assay, from the lowest: compounds 2, 1, 3 and 4 (each within the scatter of the next, the first and the last beyond it).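

Going by these compounds alone, the replacement on the nitrogen on an aromatic ring is the first change at this group alone, and in this assay it gives a 2.3-fold higher number from compound 1 to compound 4 (0.35 log units; beyond the scatter) as a modest step. The only earlier single-place step, a 1.0-fold lower number from compound 1 to compound 2 (0.02 log units; within the scatter) in the chain, stayed within the scatter, so the group on this nitrogen is the one place shown here where a single change moves the number beyond the scatter. Nothing measured here accounts for the step, which leaves its cause unexplained.

The change removes the fluorine and exchanges chlorine for bromine in a single step, so the compounds shown do not divide the effect between these two differences; 3-chlorophenyl or 3-bromo-4-fluorophenyl on the same nitrogen would separate them. Going by these compounds, it also remains open whether 3-bromophenyl would give a similar step on the chain of compound 2, and how a group such as 3-ethynylphenyl would read in the same assay.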